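Chlorophenyl Amide Expected After Chlorobenzyl: Liver-Cell Toxicity

The source may hold more compounds than are shown below. What is called first, only, known or untested is meant among the compounds shown, and "the series" means these compounds.

Compound 1 `O=C(CCSc1nnc(-c2ccncc2)s1)Nc1ccc(Cl)cc1` gives 7260 nM in an ADME assay on HepG2 cells (Homo sapiens) for cytotoxicity, with a stated time of 3 days; on this read-out higher numbers stand for lower toxicity in this test and lower numbers for higher toxicity in this test.
Compound 2 `O=C(CCSc1nnc(-c2ccncc2)s1)Nc1ccccc1` gives a value that is a limit of the assay, > 50000 nM.
Compound 3 `O=C(CCSc1nnc(-c2ccncc2)s1)NCc1ccccc1Cl` gives a value that is a limit of the assay, > 50000 nM.

Compound 3 therefore stands at the limit rather than at a measured number, one of two values sitting there (the limit of > 50000 nM in this assay, at which 2 of the 3 values shown sit). Compound 4 `O=C(CCSc1nnc(-c2ccncc2)s1)Nc1ccccc1Cl` differs from it in one place: 2-chlorophenyl in place of 2-chlorobenzyl on an amide-type nitrogen. Going by the values given here, two measured steps bear on this. The step of an at least 6.8-fold higher number from compound 1 to compound 3 (0.83 log units; beyond the scatter) shows that swapping a chlorophenyl amide for the chlorobenzyl amide moved the value from a measured number up to the limit. The step that the two limits leave unreadable from compound 2 to compound 3 cannot be read, since both ends are limits. Compound 4 returns to a chlorophenyl amide, so a move back toward a measured number is expected, as seen with compound 1 at 7260 nM, though the chloro now sits in the 2-chlorophenyl group. Compound 2, whose value is a limit of the assay, shows that not every phenyl amide is toxic here. For compound 4 the estimate is 20000 nM, with a range from 5000 nM to 60000 nM. The expected step is an at least 2.5-fold lower number from compound 3 to compound 4 (0.39 log units; beyond the scatter), downward but uncertain in size.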

Compound 4, half-maximal cytotoxic concentration: > 50000 nM
Compound 4: only a limit was reported (the forecaster's own chance of this, stated with the estimate: 45%); middle value at least 2.5-fold (0.39 log units) away from the limit.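

In this assay, 2-chlorophenyl in place of 4-chlorophenyl on the amide-type nitrogen gives an at least 6.8-fold higher number from compound 1 to compound 4 (0.83 log units; beyond the scatter). A chlorophenyl amide as such is therefore not enough to give a measured number: among the compounds shown, only compound 1 has one, and the steps linking compound 4 with compound 2 and with compound 3 cannot be read, since both ends of each are limits. Any finer ranking of these amides is out of reach, because the values crowd together at one limit: the limit of > 50000 nM in this assay, at which 3 of the 4 values shown sit.

On these data alone, the true values of compound 2, compound 3 and compound 4 remain unknown. Also open, as far as these compounds go, is whether a bromo group or an amine in place of the chloro of compound 1 would give a measured number.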